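This account rests on a few compounds, and the source may have more. Where it says the series, first, only, none or still open, it means among the compounds named here.

Measured so far in a functional assay on MDA-MB-231 cells (Homo sapiens) for cytotoxicity, read by MTT assay, with a stated time of 72 h; a lower number here means a stronger inhibitor, a higher number a weaker inhibitor:
- compound 1 `CCCCCCCCCCCCCCCCOP(=O)([O-])OCCC[N+](C)(C)Cc1ccccc1`: 43700 nM
- compound 2 `CCCCCCCCCCCCCCCCOP(=O)([O-])OCCC[N+](C)(C)C`: 61700 nM

Only these two numbers exist so far. Compound 2, at 61700 nM, cannot be ranked against the other compound, since the two lie within the scatter of each other.

The next compound to test is compound 3 `CCCCCCCCCCCCCCCCOP(=O)([O-])OCCC[n+]1ccccc1`. Its structure differs from that of compound 2 by a group of 6 heavy atoms (5 carbon, 1 nitrogen; one six-membered aromatic ring with 1 hetero atom) in place of a group of 4 heavy atoms (3 carbon, 1 nitrogen; no ring), on a saturated chain carbon, three bonds along the chain from an oxygen.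

Going by the values given here, one measured step bears on this change, and only loosely: a 1.4-fold higher number from compound 1 to compound 2 (0.15 log units; within the scatter). That step is hydrogen in place of phenyl on a saturated chain carbon bound to an amine nitrogen, so it also alters the charged end of the molecule. It shows that one such alteration left the number in this assay within the scatter. Among the compounds with values here, no measured compound carries the six-membered aromatic ring with 1 hetero atom, so this evidence is thin, and the range must stay wide.

The expected result is a 1.2-fold lower number from compound 2 to compound 3 (0.09 log units; within the scatter), which means no clear shift is expected. For compound 3 the estimated value is 50000 nM, with an expected range from 22000 nM to 100000 nM.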

Compound 3, half-maximal inhibitory concentration: 59900 nM
The estimate for compound 3 lay 1.2-fold (0.08 log units) below the measured number; measured number inside the range.
By their numbers in this assay, from the lowest: compounds 1, 3 and 2 (each within the scatter of the next).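

In this assay, putting the six-membered aromatic ring with 1 hetero atom in place of the group of 4 heavy atoms gives a 1.0-fold lower number from compound 2 to compound 3 (0.01 log units; within the scatter), and putting it in place of the group of 10 heavy atoms, which holds a six-membered aromatic ring of carbon only, gives a 1.4-fold higher number from compound 1 to compound 3 (0.14 log units; within the scatter). Three different groups, each with a net charge of +1, have now been compared on a saturated chain carbon, three bonds along the chain from an oxygen, and all three compounds lie within the scatter of one another, so this assay does not separate a nitrogen held inside an aromatic ring from the two open-chain arrangements. Nothing measured here offers an explanation for how closely these numbers agree.

The compounds shown leave open whether a group without that positive charge, such as a carboxylic acid, would give a clearly different number at this place. They also leave open whether a primary amine there, or a longer chain in the shared core, would move the number in this assay beyond the scatter.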